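Aryl Variation at the Pyrimidine Position in NF-kappa-B Inhibitors

This account rests on a few compounds, and the source may have more. Where it says the series, first, only, none or still open, it means among the compounds named here.

Measured compounds:
compound 1, `CCOC(=O)c1cnc(C(F)(F)F)nc1NN1C(=O)C=C(C)C1=O`, 1000 nM
compound 2, `CCOC(=O)c1cnc(-c2cccs2)nc1NN1C(=O)C=C(C)C1=O`, 20 nM
compound 3, `CCOC(=O)c1cnc(-c2cnc3ccccc3c2)nc1NN1C(=O)C=C(C)C1=O`, 6000 nM

The three compounds were tested in a functional assay on Jurkat cells for inhibition of nuclear factor NF-kappa-B complex (Homo sapiens); on this read-out lower numbers stand for stronger inhibition and higher numbers for weaker inhibition. Compound 2 stands lowest of the three numbers in this assay; its nearest neighbour is compound 1 at a 50-fold lower number from compound 1 to compound 2 (1.70 log units; beyond the scatter), and the furthest is compound 3 at a 300-fold higher number from compound 2 to compound 3 (2.48 log units; beyond the scatter). From compound 1 to compound 3 the change was a 6.0-fold higher number from compound 1 to compound 3 (0.78 log units; beyond the scatter).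

The unmeasured compound 4 is `CCOC(=O)c1cnc(-c2ccc(C(F)(F)F)cc2)nc1NN1C(=O)C=C(C)C1=O`. It differs from compound 2 by 4-(trifluoromethyl)phenyl in place of thiophen-2-yl on an aromatic carbon.

Within the data shown here, two measured steps bear on this change. Replacing the trifluoromethyl of compound 1 with thiophen-2-yl gave a large drop in the number, while moving from thiophen-2-yl to the larger quinolin-3-yl in compound 3 gave a large rise. A 4-(trifluoromethyl)phenyl group is larger than thiophen-2-yl but smaller than quinolin-3-yl, so a rise in the number from compound 2 is expected, though smaller than the step to compound 3. For compound 4 the step is estimated at a 15-fold higher number from compound 2 to compound 4 (1.18 log units; beyond the scatter). Compound 4 is therefore expected to give about 300 nM in this assay, within a range from 60 nM to 3000 nM.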

Compound 4, half-maximal inhibitory concentration: 400 nM
The estimate for compound 4 lay 1.3-fold (0.12 log units) below the measured number, within the range that was stated.
By their numbers in this assay, from the lowest: compound 2; then compound 4; then compound 1; then compound 3.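

In this assay, a 20-fold higher number from compound 2 to compound 4 (1.30 log units; beyond the scatter) shows that an aromatic ring at this position, between two ring nitrogen atoms, does not by itself keep the low number of compound 2, since the 4-(trifluoromethyl)phenyl group falls well short of thiophen-2-yl. The same group gives only a 2.5-fold lower number from compound 1 to compound 4 (0.40 log units; beyond the scatter), a much smaller gain over trifluoromethyl than thiophen-2-yl gave, yet a 15-fold lower number from compound 3 to compound 4 (1.18 log units; beyond the scatter) shows that it still stands well clear of quinolin-3-yl, so the three aromatic groups now spread in order from thiophen-2-yl through 4-(trifluoromethyl)phenyl to quinolin-3-yl. Compound 1, which carries no ring here, sits between compound 4 and compound 3 and so goes against any reading of this order as a simple trend with the size of the group; no measurement at hand accounts for these differences.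

The compounds shown leave open whether the rise from compound 2 to compound 4 belongs to the change from a five-membered to a six-membered ring or to the trifluoromethyl carried on that ring. A plain phenyl, a furan-2-yl or a 4-methoxyphenyl at this position would help to separate the two.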